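Swapping the aniline ring: from methoxy to chloro-fluoro

The source may report more compounds than this note shows. Statements on the series, on what has been measured and on what is new or still open speak of the compounds shown alone.

Compound 1 `C=CC(=O)Nc1cccc(NC(=O)CSc2nc(Nc3ccccc3Br)c3ccccc3n2)c1`: 15200 nM
Compound 2 `C=CC(=O)Nc1cccc(NC(=O)CSc2nc(Nc3cccc(Br)c3)c3ccccc3n2)c1`: 19400 nM
Compound 3 `C=CC(=O)Nc1cccc(NC(=O)CSc2nc(Nc3cccc(OC)c3)c3ccccc3n2)c1`: 12900 nM

All three compounds share a core and differ only in the ring attached to a nitrogen on an aromatic ring. In a functional assay on MDA-MB-231 cells (Homo sapiens) for inhibition, read by MTT assay, with a stated time of 72 h (a higher number here means a weaker inhibitor, a lower number a stronger inhibitor), compound 3 gives the lowest of the three numbers, yet the steps of a 1.2-fold lower number from compound 1 to compound 3 (0.07 log units; within the scatter) and a 1.5-fold lower number from compound 2 to compound 3 (0.18 log units; within the scatter) are both within the scatter, so the three compounds cannot be told apart on these data.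

Compound 4 `C=CC(=O)Nc1cccc(NC(=O)CSc2nc(Nc3ccc(F)c(Cl)c3)c3ccccc3n2)c1` carries a different ring at the same place: 3-chloro-4-fluorophenyl in place of 3-methoxyphenyl on a nitrogen on an aromatic ring. The measured steps that bear on such a change are a 1.3-fold higher number from compound 1 to compound 2 (0.11 log units; within the scatter), a 1.2-fold lower number from compound 1 to compound 3 (0.07 log units; within the scatter) and a 1.5-fold lower number from compound 2 to compound 3 (0.18 log units; within the scatter), all of them within the scatter. Going by the values given here, exchanging one substituted phenyl for another at this nitrogen has so far moved this assay by no more than the scatter, and no step with a halogen pair on this ring has been measured.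

The step of a 1.1-fold higher number from compound 3 to compound 4 (0.04 log units; within the scatter) is therefore expected to stay within the scatter, in no particular direction. Compound 4 is estimated at 14000 nM, with a range from 6000 nM to 33000 nM.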

Compound 4, half-maximal inhibitory concentration: 10600 nM
The estimate for compound 4 lay 1.3-fold (0.12 log units) above the measured number; the measured number falls inside the stated range.
By their numbers in this assay, from the lowest: compounds 4, 3, 1 and 2 (each within the scatter of the next).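

In this assay, the 3-chloro-4-fluorophenyl ring of compound 4 is the only ring here carrying two halogens, yet it cannot be told apart from the other three rings: a 1.2-fold lower number from compound 3 to compound 4 (0.09 log units; within the scatter), a 1.8-fold lower number from compound 2 to compound 4 (0.26 log units; within the scatter) and a 1.4-fold lower number from compound 1 to compound 4 (0.16 log units; within the scatter). Even the largest of these steps stays within the scatter, so the earlier flat picture now extends to a ring with a halogen pair. At this nitrogen, all four substituted phenyl rings shown give numbers that cannot be separated, and no measurement is available to explain this.

As far as these compounds go, whether an amine or a carboxylic acid on this ring, or a longer chain in place of the ring, would move the number beyond the scatter remains open. From the compounds shown here alone, the effect of changes elsewhere on the shared core is also open.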